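Aryl exchange on the shared core

A few compounds are considered here, and "the series" means these few. Any claim that something is new, unique, unknown or untested is made for them only; others in the source may bear on it.

Measured in a functional assay on B16-F0 cells (Mus musculus) for inhibition, read by CCK-8 assay, with a stated time of 48 h; a higher number here means a weaker inhibitor, a lower number a stronger inhibitor:
compound 1 `COc1cc(-c2ccnc3cc(-c4cccc(C#N)c4)nn23)cc(OC)c1OC`: > 10000 nM (a limit of the assay)
compound 2 `COc1cc(-c2ccnc3cc(-c4ccc5c(ccn5C)c4)nn23)cc(OC)c1OC`: 48 nM
compound 3 `C=Cc1ccc(-c2cc3nccc(-c4cc(OC)c(OC)c(OC)c4)n3n2)cc1`: 788 nM

Of the two true numbers, compound 3 at 788 nM holds the higher one, and compound 2 is its nearest neighbour. The gap is a 16-fold higher number from compound 2 to compound 3 (1.22 log units; beyond the scatter). Compound 1 stands at the limit of > 10000 nM in this assay, at which 1 of the 3 values shown sits.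

Still to be measured is compound 4 `COc1ccc(-c2cc3nccc(-c4cc(OC)c(OC)c(OC)c4)n3n2)cc1N`, in which 3-amino-4-methoxyphenyl takes the place of 4-vinylphenyl on an aromatic carbon: 3-amino-4-methoxyphenyl in place of 4-vinylphenyl on an aromatic carbon.

Among the compounds with values here, all the measured steps exchange the group at this same place, so they all bear on the change. Besides the gap above, they are an at least 200-fold lower number from compound 1 to compound 2 (2.31 log units; beyond the scatter) and an at least 12-fold lower number from compound 1 to compound 3 (1.10 log units; beyond the scatter). Each is large, so a step beyond the scatter is expected in this assay. Within the data shown here, the direction is less certain, since the incoming group matches none of the measured ones and the measured steps run both ways. Compound 2 at 48 nM shows that much lower numbers are reachable here, which tips the expectation towards a lower number. The expected change is an 8.8-fold lower number from compound 3 to compound 4 (0.94 log units; beyond the scatter). For compound 4 the estimated value is 90 nM, with an expected range of 15 nM to 600 nM.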

Compound 4, half-maximal inhibitory concentration: 88 nM
Compound 4: middle estimate off by 1.0-fold (0.01 log units), on the high side; low and high end bracket the measured number.
By their numbers in this assay, from the lowest: compounds 2 and 4 (each within the scatter of the next); then compound 3. At a limit, above all of these: compound 1.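

In this assay the exchange of 4-vinylphenyl for 3-amino-4-methoxyphenyl gives a 9.0-fold lower number from compound 3 to compound 4 (0.95 log units; beyond the scatter) and so shows that substitution on a phenyl ring at this place can shift the number beyond the scatter, with the ring itself unchanged. The comparison with the 1-methyl-1H-indol-5-yl group gives a 1.8-fold higher number from compound 2 to compound 4 (0.26 log units; within the scatter) and leaves the two compounds unordered, so that group is not the only one at this place to reach this level, although a phenyl ring as such does not suffice, as the 3-cyanophenyl and 4-vinylphenyl groups go against any such reading. The widest step now reads an at least 110-fold lower number from compound 1 to compound 4 (2.05 log units; beyond the scatter) and one end of it is a limit: the limit of > 10000 nM in this assay, at which 1 of the 4 values shown sits.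

Which of the amino and methoxy groups accounts for the step stays open, and a phenyl ring carrying only one of the two would separate them. On these data alone, how a hydroxyl or a dimethylamino group would read in place of the amino group, and whether the amino group keeps this level at another ring position, also stay open.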